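Series notes: aminobutanoyl amide to aminohydroxypropyl amine

The source may hold more compounds than are shown below. What is called first, only, known or untested is meant among the compounds shown, and "the series" means these compounds.

Measured so far in an assay on striatum for inhibition of 5-hydroxytryptamine receptor 4 (Cavia porcellus), read by radioligand binding; a lower number here means a stronger inhibitor, a higher number a weaker inhibitor:
compound 1 `COc1cc(N)c(Cl)cc1C(=O)NCC(O)CN1CCC(CN2CCC(N)CC2)CC1` gives 40.6 nM;
compound 2 `COc1cc(N)c(Cl)cc1C(=O)NC1CCN(C(=O)C2CCN(C(=O)CCCN)CC2)CC1` gives 425 nM;
compound 3 `CCCC(N)C(=O)N1CCC(CN2CCC(NC(=O)c3cc(Cl)c(N)cc3OC)CC2)CC1` gives 2.57 nM.

Compound 3 gives the lowest number of the three. Compound 1 is the nearest to it, and that gap lies beyond the scatter; compound 2 is the furthest, again beyond the scatter. Compound 4 `COc1cc(N)c(Cl)cc1C(=O)NC1CCN(CC2CCN(CC(O)CN)CC2)CC1` is not yet measured. It differs from compound 3 in one place: 3-amino-2-hydroxypropyl in place of (1-aminobutyl)carbonyl on an amine nitrogen in a ring. Within the data shown here, no pair differing in one place has been measured, so the size of this step has no precedent here. The expectation is a moderate move toward a higher number, likely beyond the scatter, since the entering group resembles the linker of compound 1, which gives 40.6 nM. Compound 4 is estimated at 10 nM, within 3 nM to 40 nM, meaning an expected step of a 3.9-fold higher number from compound 3 to compound 4 (0.59 log units; beyond the scatter).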

Compound 4, half-maximal inhibitory concentration: 14.4 nM
For compound 4 the middle estimate is 1.4-fold (0.16 log units) below the measured one; low and high end bracket the measured number.
By their numbers in this assay, from the lowest: compound 3; then compound 4; then compound 1; then compound 2.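

In this assay, among these compounds, putting 3-amino-2-hydroxypropyl in place of (1-aminobutyl)carbonyl on this ring nitrogen gives a 5.6-fold higher number from compound 3 to compound 4 (0.75 log units; beyond the scatter) and is the first measured one-place step. Compound 4 gives 14.4 nM, so inhibition persists on this nitrogen without the carbonyl of the leaving group. No evidence on the cause of this step is available.

Loss of the carbonyl and gain of the hydroxyl are joined in this one change, so their separate contributions remain open. Plain 3-aminopropyl on this nitrogen would separate them.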